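Widening the ring at the end of compound 2

A few compounds are considered here, and "the series" means these few. Any claim that something is new, unique, unknown or untested is made for them only; others in the source may bear on it.

Measured so far:
- compound 1 `CCOC(=O)C1=C(Nc2ccccc2)S/C(=C\c2ccc(Br)c(O)c2)C1=O`: 39.8%
- compound 2 `CCOC(=O)C1=C(Nc2ccccc2)S/C(=C\c2cccnc2)C1=O`: 32.1%

In a functional assay on JAR cells (Homo sapiens) for inhibition, read by MTT assay, with a stated time of 72 h, tested at 10 uM (a higher number here means more inhibition at the concentration tested (going by the name of the read-out), a lower number less inhibition), compound 2 gives 32.1%, the lower of the two numbers, with compound 1 nearest to it; the two sit within the scatter of each other, so neither can be called the stronger. Compound 3 `CCOC(=O)C1=C(Nc2ccccc2)S/C(=C\c2cc3cccnc3[nH]2)C1=O` has not yet been measured. It differs from compound 2 in one place: a group of 9 heavy atoms (7 carbon, 2 nitrogen; one five-membered aromatic ring with 1 hetero atom, one six-membered aromatic ring with 1 hetero atom) in place of a group of 6 heavy atoms (5 carbon, 1 nitrogen; one six-membered aromatic ring with 1 hetero atom), on a double-bonded chain carbon bound to a double-bonded ring carbon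

Among the measured compounds shown here, the only measured step, a number 7.7 percentage points lower from compound 1 to compound 2 (within the scatter), swapped one aromatic ring for another on the same chain carbon, and it stayed within the scatter. That step does not test a change to a two-ring group with a hydrogen-bond donor, so it bears on the new step only loosely. With nothing else to lean on, the step from compound 2 to compound 3 is expected to be about a number 2.9 percentage points higher from compound 2 to compound 3 (within the scatter), that is, no change beyond the scatter. Compound 3 is therefore estimated at 35%, with a range from 15% to 55%.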

Compound 3, a percentage reported as inhibition, at one concentration (the size of the read-out at that concentration, not a potency): 54.3%
Compound 3: the middle estimate sits 19.3 percentage points below what was measured; the range from low to high includes it.
By their numbers in this assay, from the lowest: compounds 2 and 1 (each within the scatter of the next); then compound 3.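

On the double-bonded chain carbon bound to a double-bonded ring carbon, the two single-ring groups of compound 1 and compound 2 could not be told apart, but the two-ring group shows that this position can respond to what it carries. In this assay, the change gives a number 22.2 percentage points higher from compound 2 to compound 3 (beyond the scatter), and the comparison with the other single-ring group gives a number 14.5 percentage points higher from compound 1 to compound 3 (beyond the scatter), so compound 3 stands above both. No measurement is available to explain this rise.

Still open, from the compounds shown here alone, is which feature of the entering group matters, since its added heavy atoms, its five-membered ring and its hydrogen-bond donor all arrive together in one step. Also open, going by these compounds, is how a group such as an amine or a carboxylic acid would fare at this same place.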